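Methoxy in place of hydrogen: from compound 3 to compound 4

This account rests on a few compounds, and the source may have more. Where it says the series, first, only, none or still open, it means among the compounds named here.

Compound 3 `CSc1nc(NCc2ccccc2)c2ccccc2n1` is the parent for the step considered here. In a functional assay on MCF7 cells (Homo sapiens) for cytotoxicity, read by MTT assay, with a stated time of 72 h (on this read-out lower numbers stand for higher toxicity in this test and higher numbers for lower toxicity in this test), compound 3 gives > 100000 nM, which is a limit of the assay and not a number. Two further members of the series are compound 1 `COc1ccc(CNc2nc([Se]C)nc3ccccc23)cc1` and compound 2 `CSc1nc(NCc2ccc([Se]C)cc2)c2ccccc2n1`. In this assay compound 1 gives > 100000 nM, again a limit. In this assay compound 2 gives > 100000 nM, also a limit. Among the compounds with values here, the single step between measured neighbours, a step that the two limits leave unreadable from compound 2 to compound 3, has no readable size because the limit of > 100000 nM in this assay, at which 3 of the 3 values shown sit, holds for both of its ends; no measured step in the set therefore reports a size in this assay at all.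

Compound 4 `COc1ccc(CNc2nc(SC)nc3ccccc23)cc1` differs from compound 3 by methoxy in place of hydrogen on an aromatic carbon. Compound 1 carries the same methoxy group and sits at the limit in this assay, so the methoxy has not moved any compound below the limit in the data at hand, and compound 2 and compound 3 show nothing against that.

With no readable step to lean on, the expectation is that compound 4 stays at the limit, and the estimate for compound 4 in this assay is 150000 nM with a range of 50000 nM to 500000 nM. The step that the limit leaves unreadable from compound 3 to compound 4 is thus expected to be none beyond the scatter.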

Compound 4, concentration lethal to 50% of the cells: > 100000 nM
Compound 4: only a limit was reported (the forecaster's own chance of this, stated with the estimate: 85%); the middle value is on the limit's open side.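

The steps joining compound 4 to compound 1, compound 2 and compound 3 cannot be read in this assay, because each of these compounds gives only a limit of the assay: the limit of > 100000 nM in this assay, at which 4 of the 4 values shown sit. The compounds shown leave open whether methoxy in place of hydrogen, or any exchange between the sulfur and selenium groups, changes the read-out at all.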